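Amide-nitrogen group change from compound 3 to compound 4

The compounds below may be only part of what the source reports. "The series", "measured", "known", "first", "only" and "open" are said of these compounds alone.

Measured in a physicochemical assay for solubility; a lower number here means a less soluble compound, a higher number a more soluble compound:
- compound 1 `CNC(=O)c1cc(C(=O)N[C@H]2[C@@H]3C[C@@H](OC)C[C@@H]32)n([C@@H](C)c2ccccc2)n1`: >= 150 ug/mL
- compound 2 `CCCNC(=O)c1cc(C(=O)NC)nn1[C@@H](C)c1ccccc1`: >= 132 ug/mL
- compound 3 `CNC(=O)c1cc(C(=O)N[C@H]2[C@@H]3COC[C@@H]32)c([C@@H](C)c2ccccc2)o1`: >= 131 ug/mL

All three entries are limits of the assay, not numbers. Compound 3 stands only at its limit of >= 131 ug/mL.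

Compound 4 `CNC(=O)c1cc(C(=O)N[C@H]2[C@@H]3C[C@@H](O)C[C@@H]32)c([C@@H](C)c2ccccc2)o1` is the next structure, and the change is a group of 7 heavy atoms (6 carbon, 1 oxygen; one three-membered non-aromatic ring of carbon only, one five-membered non-aromatic ring of carbon only) in place of a group of 6 heavy atoms (5 carbon, 1 oxygen; one three-membered non-aromatic ring of carbon only, one five-membered non-aromatic ring with 1 hetero atom), on an amide-type nitrogen. Within the data shown here, the one measured step that also changes a group on an amide-type nitrogen is a step that the two limits leave unreadable from compound 1 to compound 2. Its size cannot be read, so it supplies no size to carry over, and no step beyond the scatter is expected in this assay. The estimated step is a step that the limit leaves unreadable from compound 3 to compound 4. For compound 4 the estimated value is 140 ug/mL, with an expected range of 85 ug/mL to 190 ug/mL.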

Compound 4, solubility: >= 172 ug/mL
Compound 4 gave a limit, no number; the forecaster's own chance of this, stated with the estimate: 70%; at least 1.2-fold (0.08 log units) between middle value and limit.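

In this assay, among these compounds, compound 3 and compound 4 are both limits, not numbers, so no step between them can be read. The compounds shown leave open how far any of them lies past its limit in this assay, and whether the group change on the amide-type nitrogen alters the read-out at all.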